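The compounds below may be only part of what the source reports. "The series", "measured", "known", "first", "only" and "open" are said of these compounds alone.

Compound 1 `CCc1cc(Br)ccc1Nc1ncnc2cc(OC)c(OCCCSc3nc4ccccc4s3)cc12`: 5870 nM
Compound 2 `COc1ccc(Nc2ncnc3cc(OC)c(OCCCSc4nc5ccccc5s4)cc23)cc1`: 14200 nM
Compound 3 `CCCCc1nc(Cl)c(CO)n1CCCOc1cc2c(Nc3ccc(Br)cc3CC)ncnc2cc1OC`: 10600 nM

These three compounds were tested in a functional assay on MCF7 cells (Homo sapiens) for cytotoxicity, read by MTT assay, with a stated time of 24 h; on this read-out lower numbers stand for stronger inhibition and higher numbers for weaker inhibition. Compound 1 and compound 3 carry the same group on the ring nitrogen but differ in their cores: 2-butyl-4-chloro-5-(hydroxymethyl)-1H-imidazol-1-yl in place of (1,3-benzothiazol-2-yl)sulfanyl on a saturated chain carbon, three bonds along the chain from an oxygen on an aromatic ring. That change gave a 1.8-fold higher number from compound 1 to compound 3 (0.26 log units; within the scatter). Compound 1 and compound 2 share a core but differ in the group on the nitrogen: 4-methoxyphenyl in place of 4-bromo-2-ethylphenyl on a nitrogen on an aromatic ring. Here the step was a 2.4-fold higher number from compound 1 to compound 2 (0.38 log units; beyond the scatter). Compound 4, `CCCCc1nc(Cl)c(CO)n1CCCOc1cc2c(Nc3ccc(OC)cc3)ncnc2cc1OC`, has not yet been measured; it combines the core of compound 3 with the same change, (4-methoxyphenyl in place of 4-bromo-2-ethylphenyl on a nitrogen on an aromatic ring), at the same place. Among the measured compounds shown here, the step from compound 3 to compound 4 in this assay is expected to be about as large as the earlier one, because a 2.4-fold higher number from compound 1 to compound 2 (0.38 log units; beyond the scatter) is the only guide for this change, and it rests on a single pair. The estimate for compound 4 is 24000 nM, with a likely range from 10000 nM to 55000 nM. That corresponds to an expected step of a 2.3-fold higher number from compound 3 to compound 4 (0.35 log units; beyond the scatter).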

Compound 4, half-maximal inhibitory concentration: 20000 nM
For compound 4 the middle estimate is 1.2-fold (0.08 log units) above the measured one, within the range that was stated.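

In this assay, putting 4-methoxyphenyl in place of 4-bromo-2-ethylphenyl gave a 1.9-fold higher number from compound 3 to compound 4 (0.28 log units; within the scatter), and this step agrees with the one seen on the other core: the same change on two cores in this assay, a 2.4-fold higher number (0.38 log units; beyond the scatter) from compound 1 to compound 2 and a 1.9-fold higher number (0.28 log units; within the scatter) from compound 3 to compound 4, 1.3-fold (0.11 log units) apart, within the scatter of two such steps. Exchanging the (1,3-benzothiazol-2-yl)sulfanyl group for the 2-butyl-4-chloro-5-(hydroxymethyl)-1H-imidazol-1-yl group gave a 1.4-fold higher number from compound 2 to compound 4 (0.15 log units; within the scatter), which also agrees with its earlier counterpart: the same change on two cores in this assay, a 1.8-fold higher number (0.26 log units; within the scatter) from compound 1 to compound 3 and a 1.4-fold higher number (0.15 log units; within the scatter) from compound 2 to compound 4, 1.3-fold (0.11 log units) apart, within the scatter of two such steps. Among the compounds shown here, each change therefore carried over between these two cores, but each comparison rests on only two pairs, and only the step from compound 1 to compound 2 lies beyond the scatter, so this shows no more than that neither step changed much.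

On these data alone, it remains open whether the bromine or the ethyl group accounts for the step on the nitrogen's aryl group. As far as these compounds go, the behaviour of other groups, such as an unsubstituted phenyl on that nitrogen or a longer chain to the imidazole, also remains open.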